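Adding Fluorine to the Phenyl Ring of Compound 2

A few compounds are considered here, and "the series" means these few. Any claim that something is new, unique, unknown or untested is made for them only; others in the source may bear on it.

Two measured compounds share one core and differ only in the group attached at one end of it. Compound 1 `Nc1ccccc1NC(=O)c1ccc(CSC(=S)N2CCN(C(c3ccccc3)c3ccccc3)CC2)cc1` carries the larger of the two groups, and in a functional assay on HeLa cells (Homo sapiens) for antiproliferative activity, read by CCK-8 assay, with a stated time of 72 h, tested at 8 uM (a lower number here means a weaker effect, a higher number a stronger effect of the compound at the concentration tested), compound 1 gives 13.8%. Compound 2 `Nc1ccccc1NC(=O)c1ccc(CSC(=S)N2CCN(c3ccccc3)CC2)cc1` carries a plain phenyl group there, and in this assay compound 2 gives 73.1%. That is the higher of the two numbers, and compound 1 lies far below it, well beyond the usual scatter of repeated measurements.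

Compound 3 `Nc1ccccc1NC(=O)c1ccc(CSC(=S)N2CCN(c3ccccc3F)CC2)cc1` has not yet been measured. It differs from compound 2 in one place: fluoro in place of hydrogen on an aromatic carbon. Among the measured compounds shown here, no measured pair shows this kind of change, so its size cannot be read from data. Fluoro in place of hydrogen is a modest change, and the expected step of a number 5.1 percentage points lower from compound 2 to compound 3 (within the scatter) is small, within the usual scatter, with no clear direction. Compound 3 is therefore estimated to give 68% in this assay, within a range from 50% to 82%.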

Compound 3, a percentage reported as inhibition, at one concentration (the size of the read-out at that concentration, not a potency): 59.2%
Compound 3: the middle estimate sits 8.8 percentage points above what was measured, within the range that was stated.
By their numbers in this assay, from the lowest: compound 1; then compound 3; then compound 2.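

Putting one fluoro in place of a hydrogen on the aromatic ring, ortho to a large group, gives a number 13.9 percentage points lower from compound 2 to compound 3 (beyond the scatter) in this assay. Among the compounds shown here, the earlier pair showed only that exchanging the whole group at this end of the shared core can matter, whereas this step shows that even a single added atom on the phenyl ring moves the result, although compound 3 still gives 59.2%. Nothing measured here explains why this change lowers the number.

A single example cannot show whether the drop belongs to fluoro itself or to any group at this place. Going by these compounds, whether a chloro or a methoxy group in the same place would lower the number as well remains open, as does the effect of fluoro on another carbon of this ring.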